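The source may hold more compounds than are shown below. What is called first, only, known or untested is meant among the compounds shown, and "the series" means these compounds.

Compounds measured in an ADME assay on HUVEC cells (Homo sapiens) for cytotoxicity, read by MTT assay, with a stated time of 72 h; a higher number here means a weaker inhibitor, a lower number a stronger inhibitor:
- compound 1, `COc1cc(-c2nccn2CC(C)C)cc(OC)c1OC`: "not determined" (no result reported)
- compound 2, `COc1cc(-c2nccn2-c2ccc3[nH]ccc3c2)cc(OC)c1OC`: 46700 nM
- compound 3, `COc1cc(-c2nccn2-c2cccc([N+](=O)[O-])c2)cc(OC)c1OC`: > 100000 nM

Compound 1 stands without a number in this assay; its result is given as "not determined" (no result reported), so nothing places it against the other two. Compound 2 gives 46700 nM in this assay. For compound 3 only a limit is reported, > 100000 nM, which is the edge of the assay and not a number; this is the case described by the limit of > 100000 nM in this assay, at which 1 of the 3 values shown sits.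

Compound 4, `COc1ccc(-n2ccnc2-c2cc(OC)c(OC)c(OC)c2)cc1`, is the next member of the series and has not yet been tested in this assay. It differs from compound 1 in one place: 4-methoxyphenyl in place of isobutyl on an aromatic nitrogen. Going by the values given here, no step between measured compounds is known for this change, so its size cannot be read from the data. The two aryl-bearing analogues, compound 2 and compound 3, both sit at weak inhibition, and compound 4 carries an aryl group of the same kind. Compound 4 is therefore expected to be a weak inhibitor in this assay, estimated at 60000 nM with a range from 20000 nM to 150000 nM, and a fair chance that only a limit is reported.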

Compound 4, half-maximal inhibitory concentration: > 50000 nM
Compound 4 gave a limit, no number (the forecaster's own chance of this, stated with the estimate: 40%); the middle value lies beyond the limit too.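

In this assay compound 4 gives > 50000 nM, a limit and not a number. Compound 1 has no number either, so no step can be read between compound 1 and compound 4. The compounds shown leave open how far 4-methoxyphenyl in place of isobutyl shifts the read-out.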